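The source may hold more compounds than are shown below. What is called first, only, known or untested is meant among the compounds shown, and "the series" means these compounds.

Measured in a functional assay on MKN-74 cells (Homo sapiens) for antiproliferative activity, with a stated time of 24 h; a higher number here means a weaker inhibitor, a lower number a stronger inhibitor:
Compound 1, `NC(=O)c1c(NC(=O)c2ccccc2Cl)sc2c1CCN(Cc1ccc([N+](=O)[O-])cc1)C2`: 31500 nM
Compound 2, `NC(=O)c1c(NC(=O)c2ccccc2Cl)sc2c1CCN(Cc1ccc(Cl)cc1Cl)C2`: 16300 nM

Compound 2 carries the lower of these two numbers, but the step of a 1.9-fold lower number from compound 1 to compound 2 (0.29 log units; within the scatter) lies within the scatter, so the two compounds cannot be told apart on this evidence.

Compound 3, `Cc1ccccc1NC(=S)N1CCc2c(sc(NC(=O)c3ccccc3Cl)c2C(N)=O)C1`, differs from compound 2 by a group of 10 heavy atoms (8 carbon, 1 nitrogen, 1 sulfur; one six-membered aromatic ring of carbon only) in place of a group of 9 heavy atoms (7 carbon, 2 chlorine; one six-membered aromatic ring of carbon only), on an amine nitrogen in a ring.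

Among the measured compounds shown here, only one measured step bears on this change: the exchange of one group at the same place, from compound 1 to compound 2, which gave a 1.9-fold lower number from compound 1 to compound 2 (0.29 log units; within the scatter), a shift inside the scatter. For the measured compounds named here, the group entering in compound 3 is of a different kind from either of those seen, so the single step gives only a weak guide. The expectation is therefore a step of a 1.1-fold lower number from compound 2 to compound 3 (0.04 log units; within the scatter), with no direction beyond the scatter. Compound 3 is estimated at 15000 nM, within a range from 4000 nM to 50000 nM.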

Compound 3, half-maximal inhibitory concentration: 11700 nM
The estimate for compound 3 lay 1.3-fold (0.11 log units) above the measured number, and the stated range covers the measured number.
By their numbers in this assay, from the lowest: compounds 3, 2 and 1 (each within the scatter of the next, the first and the last beyond it).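

The amine nitrogen in a ring can carry a group of a quite different kind, with 1 hydrogen-bond donor, 1 hydrogen-bond acceptor and a sulfur atom, without a clear shift in this assay: the change gives a 1.4-fold lower number from compound 2 to compound 3 (0.14 log units; within the scatter), so these two compounds cannot be told apart. Among the compounds shown here, the three compounds now also yield the first step beyond the scatter at this position, a 2.7-fold lower number from compound 1 to compound 3 (0.43 log units; beyond the scatter), although it is only modest. Nothing measured here explains either step.

From the compounds shown here alone, all three groups contain a six-membered aromatic ring of carbon only, so it remains open how a short alkyl chain or a plain hydrogen on this nitrogen would fare. Going by these compounds, the role of the sulfur also remains open, and the matching urea, with oxygen in its place, could help to test it.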